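Swapping Benzyl for tert-Butyl on a Shared Core

A few compounds are considered here, and "the series" means these few. Any claim that something is new, unique, unknown or untested is made for them only; others in the source may bear on it.

Of the compounds shown here, three built on one shared core have been tested in a functional assay on COLO 205 cells (Homo sapiens) for inhibition, read by MTT assay, with a stated time of 24 h; on this read-out higher numbers stand for weaker inhibition and lower numbers for stronger inhibition. Compound 1 `COc1ccc(-n2cc(/C=[N+](\[O-])Cc3ccccc3)nn2)cc1` reaches only the edge of the assay: in this assay compound 1 gives > 100000 nM, which is a limit and not a number. Compound 2 `CCCCCCCCn1cc(/C=[N+](\[O-])Cc2ccccc2)nn1` gives > 100000 nM in this assay, again a limit. Compound 3 `CCCCCCCCCCn1cc(/C=[N+](\[O-])Cc2ccccc2)nn1` gives > 100000 nM in this assay, once more a limit. Within the data shown here, the one step between measured compounds, a step that the two limits leave unreadable from compound 2 to compound 3, has no readable size because both of its ends sit at the limit of > 100000 nM in this assay, at which 3 of the 3 values shown sit. Compound 3 therefore stands nowhere on a scale of numbers; it shares the limit with compound 1 and compound 2, and no order among the three can be drawn.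

Compound 4 `CCCCCCCCCCn1cc(/C=[N+](\[O-])C(C)(C)C)nn1` differs from compound 3 by tert-butyl in place of benzyl on a double-bonded nitrogen. Among the measured compounds shown here, no measured step bears on this change: the only measured step alters the chain on the aromatic nitrogen, not the group on the double-bonded nitrogen, and even that step is unreadable. Nothing in the set points to a direction, so the expectation rests on the absence of any measured activity. Compound 4 is expected to give about 150000 nM in this assay, within a range from 30000 nM to 1000000 nM. The step from compound 3 to compound 4 is estimated as a step that the limit leaves unreadable from compound 3 to compound 4, most likely ending at the limit again.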

Compound 4, half-maximal inhibitory concentration: 22100 nM
Compound 4: the middle estimate sits 6.8-fold (0.83 log units) above what was measured; the measured number lies below the stated range.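

In this assay, among these compounds, tert-butyl in place of benzyl on the double-bonded nitrogen gives an at least 4.5-fold lower number from compound 3 to compound 4 (0.65 log units; beyond the scatter), the first step in this set with a readable direction and the first change at this position. Among the compounds shown here, it shows that the group on the double-bonded nitrogen can move the read-out, with compound 4 giving the only number so far rather than a limit. The step is a minimum and not an exact size, and most of the set still stands at the edge of the assay: the limit of > 100000 nM in this assay, at which 3 of the 4 values shown sit.

The change swaps a group with a six-membered aromatic ring and 7 heavy atoms for one with no ring and 4 heavy atoms, so these compounds cannot say whether losing the ring or reducing the size matters, and a cyclohexyl or isopropyl group at the same place would help to separate the two. As far as these compounds go, it also remains open whether tert-butyl would give a similar step on the shared core when paired with the chain of compound 2 or the aromatic group of compound 1.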